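A Methylene Added to the Ring on Nitrogen

The compounds below may be only part of what the source reports. "The series", "measured", "known", "first", "only" and "open" are said of these compounds alone.

Compound 1 `CN(C)C(=O)CN1CCC(c2cc3c(-c4ccc(=O)n(C5CCOCC5)c4)ccnc3[nH]2)CC1` was tested in an ADME assay on microsomes from liver (Homo sapiens) for metabolic stability (on this read-out lower numbers stand for slow clearance and higher numbers for fast clearance), where compound 1 gives 8.2 uL/min. Compound 2 `COc1cc(F)ccc1-c1ccnc2[nH]c(C3CCOCC3)cc12` gives 10 uL/min in this assay; the two numbers lie within the scatter of each other, and compound 1 stands as the lower of the two numbers reported. For compound 3 `CC(C)n1cc(-c2ccnc3[nH]c(C4CCN(CC(=O)N5CCCCC5)CC4)cc23)ccc1=O` the read-out in this assay is > 300 uL/min, which is the limit of > 300 uL/min in this assay, at which 1 of the 3 values shown sits, a limit of the assay and not a number.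

Compound 4 `CN(C)C(=O)CN1CCC(c2cc3c(-c4ccc(=O)n(CC5CCOCC5)c4)ccnc3[nH]2)CC1` is not yet measured. It differs from compound 1 in one place: (oxan-4-yl)methyl in place of oxan-4-yl on an aromatic nitrogen. Among the measured compounds shown here, no step between measured compounds tests this change, so the expectation rests on compound 1 alone. The step of a 1.8-fold higher number from compound 1 to compound 4 (0.26 log units; within the scatter) is expected to be small and upward, at most slightly beyond the scatter. For compound 4 the estimate in this assay is 15 uL/min, with a range from 6 uL/min to 40 uL/min.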

Compound 4, intrinsic clearance in a liver preparation (reported as CLH), per the amount of preparation that the assay uses: 20 uL/min
Beside the measured number, compound 4's estimate is 1.3-fold (0.12 log units) below it, and the stated range covers the measured number.
By their numbers in this assay, from the lowest: compounds 1, 2 and 4 (each within the scatter of the next, the first and the last beyond it). At a limit, above all of these: compound 3.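

Setting (oxan-4-yl)methyl in place of oxan-4-yl on an aromatic nitrogen gives a 2.4-fold higher number from compound 1 to compound 4 (0.39 log units; beyond the scatter) in this assay. This is the only step shown at this position, and it shows that the read-out responds to this single change while the rest of the structure stays the same. Nothing measured here gives a cause for this step.

Going by these compounds, whether a longer chain or an open-chain ether such as 2-methoxyethyl on that nitrogen would move the number further remains open. So does whether an amine in place of the ring oxygen would give a step of the same direction.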